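The source may hold more compounds than are shown below. What is called first, only, known or untested is meant among the compounds shown, and "the series" means these compounds.

Measured in a toxicity assay on CHO cells (Cricetulus griseus) for cytotoxicity, read by WST assay, with a stated time of 24 h; on this read-out higher numbers stand for weaker inhibition and lower numbers for stronger inhibition:

- Compound 1 `CC(C)=CCCC(C)=CCNCCCN`: > 150000 nM (a limit of the assay, not a number)
- Compound 2 `CC(C)=CCC/C(C)=C\CCC(C)=CCNCCN`: 32300 nM
- Compound 3 `CC(C)=CCC/C(C)=C\CCC(C)=CCNCCCN`: 32100 nM

Compound 3, at 32100 nM, and compound 2, at 32300 nM, lie within the scatter of each other. Compound 1 is known only through its limit. Against that limit, the step of an at least 4.6-fold lower number from compound 1 to compound 3 (0.66 log units; beyond the scatter) goes beyond the scatter, but it concerns 3-methylbut-2-en-1-yl in place of hydrogen, a different change from the one followed here.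

Compound 4 `CC(C)=CCC/C(C)=C\CCC(C)=CCNCCCCN` differs from compound 3 in one place: aminomethyl in place of amino on a saturated chain carbon, three bonds along the chain from an amine nitrogen. The 3-aminopropyl group becomes 4-aminobutyl, with aminomethyl in place of amino on a saturated chain carbon, three bonds along the chain from an amine nitrogen.

The same kind of change, made two bonds along the chain from an amine nitrogen, gave the step of a 1.0-fold lower number from compound 2 to compound 3 (0.00 log units; within the scatter), which stays within the scatter. That single precedent leads to the expectation of no real shift in this assay, and the expected step is a 1.1-fold lower number from compound 3 to compound 4 (0.03 log units; within the scatter). For compound 4 the estimated value is 30000 nM, with an expected range from 15000 nM to 60000 nM.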

Compound 4, half-maximal inhibitory concentration: 18100 nM
Beside the measured number, compound 4's estimate is 1.7-fold (0.22 log units) above it; the measured number falls inside the stated range.
By their numbers in this assay, from the lowest: compounds 4, 3 and 2 (each within the scatter of the next). At a limit, above all of these: compound 1.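

In this assay, going from 3-aminopropyl to 4-aminobutyl gives a 1.8-fold lower number from compound 3 to compound 4 (0.25 log units; within the scatter), so this change, made three bonds along the chain from an amine nitrogen, stays within the usual scatter just as the same change made two bonds along did. Read end to end, going from 2-aminoethyl to 4-aminobutyl gives a 1.8-fold lower number from compound 2 to compound 4 (0.25 log units; within the scatter), so the chain lengths shown here cannot be told apart on this read-out, even across the widest gap available. Nothing given here explains these small steps.

Going by these compounds, whether a longer chain, such as 5-aminopentyl or 6-aminohexyl, would also stay within the scatter remains open. So does what would happen if the amine at the chain end gave way to a hydroxyl group or a carboxylic acid.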